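This account rests on a few compounds, and the source may have more. Where it says the series, first, only, none or still open, it means among the compounds named here.

Working notes on the series. All three measured compounds share one core and differ only in the aryl group on a nitrogen on an aromatic ring. In a functional assay on MCF7 cells (Homo sapiens) for antiproliferative activity, read by MTT assay, with a stated time of 24 h (a lower number here means a stronger inhibitor, a higher number a weaker inhibitor), compound 1, `CNC(=O)c1ccccc1Oc1nc(Nc2ccc(Br)cc2)ncc1Br`, reaches only the limit of > 50000 nM, a limit and not a number. Compound 2, `CNC(=O)c1ccccc1Oc1nc(Nc2ccccc2F)ncc1Br`, likewise gives only the limit of > 50000 nM in this assay. Compound 3, `CNC(=O)c1ccccc1Oc1nc(Nc2cccc(Br)c2)ncc1Br`, is the one compound with a number in this assay, at 42500 nM, and therefore stands alone among the numbers shown. The step of an at least 1.1-fold lower number from compound 1 to compound 3 (0.07 log units; that floor lies within the scatter) and the step of an at least 1.1-fold lower number from compound 2 to compound 3 (0.07 log units; that floor lies within the scatter) both rest on the limit of > 50000 nM in this assay, at which 2 of the 3 values shown sit, and read only as floors within the scatter, while the step that the two limits leave unreadable from compound 1 to compound 2 cannot be read at all. Compound 4, `CNC(=O)c1ccccc1Oc1nc(Nc2ccccc2OC)ncc1Br`, carries the change (2-methoxyphenyl in place of 3-bromophenyl on a nitrogen on an aromatic ring). Within the data shown here, no measured step tracks a methoxy group, so the expectation for compound 4 is only that the step of a 1.2-fold higher number from compound 3 to compound 4 (0.07 log units; within the scatter) stays within the scatter. Compound 4 is estimated at 50000 nM, in the range 20000 nM to 150000 nM.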

Compound 4, half-maximal inhibitory concentration: > 50000 nM
Compound 4 ended at the assay's limit; the forecaster's own chance of this, stated with the estimate: 55%; the middle value lies on the limit itself.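

In this assay the change to the 2-methoxyphenyl group gives an at least 1.1-fold higher number from compound 3 to compound 4 (0.07 log units; that floor lies within the scatter), so a methoxy-bearing aryl group on this nitrogen is not separated from the 3-bromophenyl group by more than the scatter. The steps from compound 1 and from compound 2 to compound 4 cannot be read, which leaves methoxy in place of fluoro without a size. The new result adds a further compound to the limit, not a second number: the limit of > 50000 nM in this assay, at which 3 of the 4 values shown sit.

Among these compounds, compound 3 still holds the only number, at 42500 nM, so no trend among the aryl groups can be drawn from these compounds. As far as these compounds go, whether an amine or a carboxylic acid on this aryl ring would give a clearly lower number stays open.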